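A few compounds are considered here, and "the series" means these few. Any claim that something is new, unique, unknown or untested is made for them only; others in the source may bear on it.

Working notes on the series, read in a functional assay on K562 cells (Homo sapiens), read by MTT assay, with a stated time of 72 h; on this read-out higher numbers stand for weaker inhibition and lower numbers for stronger inhibition.

Compound 1 `COc1ncnc2c1c(-c1cccs1)cn2[C@@H]1O[C@H](CO)[C@@H](O)[C@H]1O` gives 6200 nM. Compound 2 `CSc1ncnc2c1c(-c1cccs1)cn2[C@@H]1O[C@H](CO)[C@@H](O)[C@H]1O` shows only a limit of the assay, > 20000 nM. Compound 3 `CN(C)c1ncnc2c1c(-c1cccs1)cn2[C@@H]1O[C@H](CO)[C@@H](O)[C@H]1O` likewise reaches only a limit, > 20000 nM. Two of the three values sit at the limit of > 20000 nM in this assay, at which 2 of the 3 values shown sit, so compound 2 stands at the weak end of what this assay can report. The measured steps are an at least 3.2-fold higher number from compound 1 to compound 2 (0.50 log units; beyond the scatter) and an at least 3.2-fold higher number from compound 1 to compound 3 (0.50 log units; beyond the scatter); the step that the two limits leave unreadable from compound 2 to compound 3 cannot be read.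

Compound 4 `C#Cc1cn([C@@H]2O[C@H](CO)[C@@H](O)[C@H]2O)c2ncnc(SC)c12` differs from compound 2 by ethynyl in place of thiophen-2-yl on an aromatic carbon. Going by the values given here, none of the measured steps touches this position: every change so far sits on the methoxy, methylsulfanyl or dimethylamino carbon, so no step bears on the ethynyl replacement. Among the compounds with values here, with compound 2 already at a limit, the expectation is that compound 4 stays near that limit, with no step readable beyond the scatter. Compound 4 is expected at 20000 nM, within 5000 nM to 60000 nM. The expected step is a number no higher from compound 2 to compound 4 (the limit leaves the size open).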

Compound 4, half-maximal inhibitory concentration: 70 nM
Compound 4: the middle estimate sits 290-fold (2.46 log units) above what was measured; measured number below the stated range.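

In this assay, going by these compounds alone, the earlier compounds all carry thiophen-2-yl at this position and vary only the methoxy, methylsulfanyl or dimethylamino group, so they could not show how much this position matters. Ethynyl in place of thiophen-2-yl gives an at least 280-fold lower number from compound 2 to compound 4 (2.45 log units; beyond the scatter), which shows that this position alone can move a compound away from the weak end of the read-out. The value of compound 2 is only a limit, so the step has a floor but no exact size: the limit of > 20000 nM in this assay, at which 2 of the 4 values shown sit.

The compounds shown do not tell whether ethynyl gives a similar step alongside methoxy or dimethylamino. They also do not separate the triple bond from the loss of the ring, which a vinyl group or a phenyl-substituted ethynyl group at the same position would address.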